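This account rests on a few compounds, and the source may have more. Where it says the series, first, only, none or still open, it means among the compounds named here.

Measured so far:
compound 1 `C=C1CC[C@@H]2[C@](C)(CO[Si](C)(C)C(C)(C)C)[C@H](O)CC[C@@]2(C)[C@@H]1C/C=C1/C(=O)OC[C@H]1OC(C)=O` — 10.4 uM
compound 2 `C=C1CC[C@@H]2[C@](C)(CO[Si](C)(C)C(C)(C)C)[C@H](O)CC[C@@]2(C)[C@@H]1C/C=C1/C(=O)OC[C@H]1O` — 47 uM

Both compounds were tested in a functional assay on MCF7 cells (Homo sapiens) for cytotoxicity, read by sulforhodamine B assay; on this read-out higher numbers stand for an effect only at larger amounts of compound and lower numbers for an effect already at smaller amounts. For the measured compounds named here, compound 2 stands at the higher of the two numbers; the only neighbour, compound 1, sits a 4.5-fold higher number from compound 1 to compound 2 (0.66 log units; beyond the scatter), and that step exchanges a hydrogen for an acetyl on an oxygen on a saturated carbon.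

Compound 3 `C=C1CC[C@@H]2[C@](C)(CO[Si](C(C)C)(C(C)C)C(C)C)[C@H](O)CC[C@@]2(C)[C@@H]1C/C=C1/C(=O)OC[C@H]1O` keeps the free hydroxyl of compound 2 and differs elsewhere: a group of 10 heavy atoms (9 carbon, 1 silicon; no ring) in place of a group of 7 heavy atoms (6 carbon, 1 silicon; no ring), on an oxygen on a saturated carbon. Going by the values given here, no measured step touches this silicon-bearing group, so the data give no direct guide; the one step seen concerns a different oxygen and is itself only modest in this assay. The change therefore is expected to bring no step beyond the usual scatter, no change at the digits printed from compound 2 to compound 3 (within the scatter), with the uncertainty spread evenly in both directions.

Compound 3 is estimated to give 47 uM in this assay, within a range from 15 uM to 150 uM.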

Compound 3, concentration for half-maximal effect: 2.88 uM
Estimate against measurement, compound 3: 16-fold (1.21 log units) above; the whole stated range lies above it.
By their numbers in this assay, from the lowest: compound 3; then compound 1; then compound 2.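

Swapping the group of 7 heavy atoms (6 carbon, 1 silicon; no ring) for the group of 10 heavy atoms (9 carbon, 1 silicon; no ring) on this oxygen gives a 16-fold lower number from compound 2 to compound 3 (1.21 log units; beyond the scatter) in this assay and so shows that the silicon-bearing group is not a silent part of the molecule. For the compounds shown here, this step counts as large, whereas the only earlier step, at the other oxygen, was a 4.5-fold higher number from compound 1 to compound 2 (0.66 log units; beyond the scatter) and counts as modest. No available evidence gives a reason for this change.

On these data alone, with only these two silicon-bearing groups, it remains open whether the number would keep falling with a longer chain on the silicon or a phenyl group there. As far as these compounds go, it is also open how a plain hydroxyl at this oxygen would compare, and whether an acetyl on the other oxygen would have the same effect alongside the larger group.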